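A Shorter Unsaturated Chain on a Growth Inhibitor

The source may report more compounds than this note shows. Statements on the series, on what has been measured and on what is new or still open speak of the compounds shown alone.

For the measured compounds named here, in a functional assay on MDA-MB-231 cells (Homo sapiens) for antiproliferative activity, read by sulforhodamine B assay (a lower number here means a stronger inhibitor of growth, a higher number a weaker inhibitor of growth), compound 1 `CC(C)CCCOc1cccc(O)c1C(=O)/C=C/c1ccc(O)cc1` gives 3480 nM and holds the lower of the two numbers known, while compound 2 `CC(C)(C)CCOc1cccc(O)c1C(=O)/C=C/c1ccc(C(=O)O)cc1` gives 11200 nM and sits higher, beyond the scatter. Compound 3 `CC(C)=CCOc1cccc(O)c1C(=O)/C=C/c1ccc(O)cc1` keeps the core of compound 1 and alters one chain. The change is 2-methylprop-1-en-1-yl in place of isopentyl on a saturated chain carbon bound to an oxygen on an aromatic ring and it sits on a saturated chain carbon bound to an oxygen on an aromatic ring. Going by the values given here, no measured pair shows this change, so the expected step of a 1.3-fold higher number from compound 1 to compound 3 (0.11 log units; within the scatter) is small, leaning towards weaker inhibition but within the scatter. For compound 3 the estimated value is 4500 nM (range 1900 nM to 11000 nM).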

Compound 3, concentration for 50% growth inhibition: > 30000 nM
Compound 3 gave a limit, no number; the forecaster's own chance of this, stated with the estimate: 3%; at least 6.6-fold (0.82 log units) between middle value and limit.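

Putting 2-methylprop-1-en-1-yl in place of isopentyl is no minor edit at this position: in this assay it gives an at least 8.6-fold higher number from compound 1 to compound 3 (0.93 log units; beyond the scatter). For the compounds shown here, the earlier compounds differ in more than one place, so only this pair shows that growth inhibition responds strongly to this chain alone. Compound 3 gives a limit, not a number: the limit of > 30000 nM in this assay, at which 1 of the 3 values shown sits.

The compounds shown do not separate the loss of a chain carbon from the arrival of the double bond. A saturated 2-methylpropyl chain in the same place would tell these two apart.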